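This account rests on a few compounds, and the source may have more. Where it says the series, first, only, none or still open, it means among the compounds named here.

Of the compounds shown here, three sharing one core have been tested in a functional assay on PC-9 cells (Homo sapiens) for inhibition, read by MTT assay, with a stated time of 48 h, tested at 10 uM; a higher number here means more inhibition at the concentration tested (going by the name of the read-out), a lower number less inhibition. Compound 1 `Cc1cc(F)cc(Nc2cc(NC(=O)Nc3c(Cl)cccc3Cl)ncn2)c1` gives 80%. Compound 2 `COc1cc(Br)ccc1Nc1cc(NC(=O)Nc2c(Cl)cccc2Cl)ncn1` gives 90.5%, and compound 3 `COc1ccc(Br)cc1Nc1cc(NC(=O)Nc2c(Cl)cccc2Cl)ncn1` gives 69%. Compound 3 therefore stands lowest of the three numbers, with compound 1 the nearest to it and compound 2 the furthest away.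

The next compound, compound 4 `COc1ccc(Nc2cc(NC(=O)Nc3c(Cl)cccc3Cl)ncn2)cc1C`, differs from compound 3 in one place: 4-methoxy-3-methylphenyl in place of 5-bromo-2-methoxyphenyl on a nitrogen on an aromatic ring. All three measured steps concern the same ring on that nitrogen, and all were modest: a number 10.5 percentage points higher from compound 1 to compound 2 (beyond the scatter), a number 11 percentage points lower from compound 1 to compound 3 (beyond the scatter), and a number 21.5 percentage points lower from compound 2 to compound 3 (beyond the scatter). Moving the bromine from one ring position to another accounted for the largest of these, so rebuilding the ring again may well move the number by a similar modest amount. Since compound 3 is already the lowest and exchanging this ring has so far shifted the read-out in both directions, an upward step is expected, a number 9 percentage points higher from compound 3 to compound 4 (within the scatter). Compound 4 is thus estimated at 78%, within a range from 60% to 92%.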

Compound 4, a percentage reported as inhibition, at one concentration (the size of the read-out at that concentration, not a potency): 80.1%
For compound 4 the middle estimate is 2.1 percentage points below the measured one, and the stated range covers the measured number.
By their numbers in this assay, from the lowest: compound 3; then compounds 1 and 4 (each within the scatter of the next); then compound 2.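

Replacing 5-bromo-2-methoxyphenyl with 4-methoxy-3-methylphenyl on this nitrogen gives a number 11.1 percentage points higher from compound 3 to compound 4 (beyond the scatter) in this assay, so a ring without bromine can give a higher number than a bromine-bearing one. The other bromine-bearing ring, 4-bromo-2-methoxyphenyl, still gives the highest number, with a number 10.4 percentage points lower from compound 2 to compound 4 (beyond the scatter) when 4-methoxy-3-methylphenyl takes its place. The two bromine-free rings, 3-fluoro-5-methylphenyl and 4-methoxy-3-methylphenyl, carry different groups yet cannot be told apart, with a number 0.1 percentage points higher from compound 1 to compound 4 (within the scatter) in this single-concentration read-out.

Still open, going by these compounds, is how a ring carrying an amine or a carboxylic acid on this nitrogen would behave. Nothing available explains why the number moves with these rings.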